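The compounds below may be only part of what the source reports. "The series", "measured", "known", "first", "only" and "open" are said of these compounds alone.

Three compounds share one core and differ only in the aryl group carried on a saturated ring carbon. Compound 1 `Fc1ccc([C@@H]2C[C@@H]3Cc4ccc5ccccc5c4N2O3)cc1` was examined in an ADME assay on THP-1 cells (Homo sapiens) for cytotoxicity, read by MTT assay, with a stated time of 72 h; a higher number here means that more compound is tolerated, a lower number that less compound is tolerated. In this assay compound 1 gives > 300000 nM, which is a limit of the assay rather than a number. In this assay compound 2 `Clc1ccc([C@@H]2C[C@@H]3Cc4ccc5ccccc5c4N2O3)cc1` gives > 300000 nM, again a limit. In this assay compound 3 `Clc1cccc([C@@H]2C[C@@H]3Cc4ccc5ccccc5c4N2O3)c1` gives > 300000 nM, also a limit. All three results thus sit at the limit of > 300000 nM in this assay, at which 3 of the 3 values shown sit, so compound 3 stands level with the others, and between them there is only a step that the two limits leave unreadable from compound 1 to compound 2, a step that the two limits leave unreadable from compound 1 to compound 3 and a step that the two limits leave unreadable from compound 2 to compound 3, none of which has a readable size.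

Compound 4 `Brc1cccc([C@@H]2C[C@@H]3Cc4ccc5ccccc5c4N2O3)c1` has not yet been measured. It differs from compound 3 by bromo in place of chloro on an aromatic carbon. For the measured compounds named here, no measured step offers a readable size or direction, so the step expected from compound 3 to compound 4 is a number no higher from compound 3 to compound 4 (the limit leaves the size open), meaning nothing beyond the scatter. In this assay compound 4 is therefore estimated at 300000 nM, within a range from 100000 nM to 1000000 nM, most probably reported once more as a limit.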

Compound 4, half-maximal cytotoxic concentration: > 250000 nM
Compound 4: no number, only a limit (the forecaster's own chance of this, stated with the estimate: 85%); the middle value is on the limit's open side.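

Compound 4 gives > 250000 nM, which is a limit and not a number, so its steps from compound 1, compound 2 and compound 3 cannot be read. The compounds shown leave open what concentration of any of them harms the cells in this assay, and whether swapping the aryl group changes it.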